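Trimethoxyphenyl pyrazolyl chalcones: cytotoxicity notes

The source may report more compounds than this note shows. Statements on the series, on what has been measured and on what is new or still open speak of the compounds shown alone.

Measured so far:
- compound 1 `COc1cc(-c2cc(/C=C/C(=O)c3ccc(N)cc3)[nH]n2)cc(OC)c1OC` gives -82%
- compound 2 `COc1ccc(-c2cc(/C=C/C(=O)c3ccc(N)cc3)[nH]n2)cc1OC` gives -81%
- compound 3 `COc1cc(C(=O)/C=C/c2cc(-c3cc(OC)c(OC)c(OC)c3)n[nH]2)cc(OC)c1OC` gives -95%

All three were read in a functional assay on LOX IMVI cells (Homo sapiens) for cytotoxicity, read by sulforhodamine B assay, with a stated time of 48 h, tested at 100 uM; on this read-out lower numbers stand for a stronger effect and higher numbers for a weaker effect at the one concentration tested. Between compound 1 and compound 2 the change is hydrogen in place of methoxy on an aromatic carbon, and the step is a number 1 percentage points higher from compound 1 to compound 2 (within the scatter). Compound 3 stands apart from compound 1 and compound 2 by more than that; how its core differs from the core of compound 1 is not broken down here.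

Compound 4 `COc1ccc(-c2cc(/C=C/C(=O)c3cc(OC)c(OC)c(OC)c3)[nH]n2)cc1OC` has not been measured. It differs from compound 3 by hydrogen in place of methoxy on an aromatic carbon, the same change as from compound 1 to compound 2, at a place described in the same words. Because that earlier step was a number 1 percentage points higher from compound 1 to compound 2 (within the scatter), the expected step here is also small: a number 2 percentage points higher from compound 3 to compound 4 (within the scatter). For compound 4 the estimate in this assay is -93%, expected between -100% and -82%.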

Compound 4, a percentage reported as activity, at one concentration (the size of the read-out at that concentration, not a potency): -69%
For compound 4 the middle estimate is 24 percentage points below the measured one, and the stated range ends below it.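

Hydrogen in place of methoxy on an aromatic carbon gives a number 26 percentage points higher from compound 3 to compound 4 (beyond the scatter) in this assay. The change therefore does not carry over with the same size from the core of compound 1 to the core of compound 3, and an estimate taken from one core cannot be relied on for the other: the same change on two cores in this assay, a number 1 percentage points higher (within the scatter) from compound 1 to compound 2 and a number 26 percentage points higher (beyond the scatter) from compound 3 to compound 4, 25 percentage points apart, beyond the scatter of two such steps. This rests on two pairs read at one concentration in one cell line, so it does not show what sets the two cores apart or how the change would behave on a further core.

Still open, on these data alone, is how a hydroxyl or an amine in place of this methoxy would read in this assay. Also open, as far as these compounds go, is whether a longer alkoxy chain at that place would read nearer to compound 3 or to compound 4.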